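Compound 3 to compound 4: chloro replaced by nitro

The source may report more compounds than this note shows. Statements on the series, on what has been measured and on what is new or still open speak of the compounds shown alone.

compound 1 `CCOC(=O)c1nn(-c2ccccc2)c(-c2ccc(Cl)cc2)c1CNC(C)(C)C` gives 134 nM; > 559000 nM (2 entries) (two entries)
compound 2 `CCOC(=O)c1nn(-c2ccc(Cl)cc2)c(-c2ccc([N+](=O)[O-])cc2)c1CNC(C)(C)C` gives 206000 nM; 16100 nM (2 entries) (two numbers)
compound 3 `CC(C)(C)NCc1c(C(=O)O)nn(-c2ccccc2)c1-c1ccc(Cl)cc1` gives > 652000 nM (a limit of the assay)

These values all come from a functional assay on OVCAR-3 cells (Homo sapiens) for inhibition, read by sulforhodamine B assay, with a stated time of 48 h (a higher number here means a weaker inhibitor of growth, a lower number a stronger inhibitor of growth), and they are few. Compound 3 stands on a limit alone, with no number for its growth inhibition. The entries of compound 1 do not agree with each other, so it offers no firm reference point.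

The next compound is compound 4 `CC(C)(C)NCc1c(C(=O)O)nn(-c2ccccc2)c1-c1ccc([N+](=O)[O-])cc1`, which has nitro in place of chloro on an aromatic carbon, 4-chlorophenyl to 4-nitrophenyl (nitro in place of chloro on an aromatic carbon). Among the compounds with values here, no measured pair isolates this change. Compound 2 also carries the 4-nitrophenyl group and gives 206000 nM; 16100 nM (2 entries) as two entries lying well apart, so it supports only a loose expectation of weak inhibition for compound 4. The expected change is an at least 1.4-fold lower number from compound 3 to compound 4 (0.16 log units; that floor lies within the scatter) and nothing beyond the usual scatter is expected, with any shift leaning slightly towards stronger inhibition. A report as a limit alone is more likely than a number. For compound 4 the estimated value is 450000 nM, with an expected range from 60000 nM to 800000 nM if a number is obtained.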

Compound 4, concentration for 50% growth inhibition: > 634000 nM
Compound 4 was reported as a limit; the forecaster's own chance of this, stated with the estimate: 60%; at least 1.4-fold (0.14 log units) between middle value and limit.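

In this assay, compound 3 and compound 4 are both reported only as limits, and no step can be read between them. The compounds shown leave open whether nitro in place of chloro on an aromatic carbon changes growth inhibition at all, and in which direction any such change would run.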